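Hydroxamate series: shortening the amide-borne chain

The compounds below may be only part of what the source reports. "The series", "measured", "known", "first", "only" and "open" are said of these compounds alone.

Two compounds of this series have a value in a physicochemical assay for lipophilicity; on this read-out higher numbers stand for higher lipophilicity and lower numbers for lower lipophilicity. Compound 1 `NC(=O)C[C@H](NC(=O)c1ccc(C#Cc2ccccc2)cc1)C(=O)NO` gives 1 in this assay. Compound 2 `CC(C)(NC(=O)c1ccc(C#Cc2ccccc2)cc1)C(=O)NO` gives 3 in this assay. Of the two numbers, compound 2 stands highest, and its nearest neighbour compound 1 lies a step lower that is beyond the usual scatter. Among the compounds with values here, no pair of measured compounds differs in one place only, so no measured step is available to lean on.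

The next compound, compound 3 `O=C(CNC(=O)c1ccc(C#Cc2ccccc2)cc1)NO`, shares the core of compound 2 and differs from it at one point: (hydroxycarbamoyl)methyl in place of 1-(hydroxycarbamoyl)-1-methylethyl on an amide-type nitrogen. The change removes part of the chain on the amide-type nitrogen while keeping the hydroxycarbamoyl end.

Given that compound 2 sits at 3 in this assay and that the entering group is the smaller of the two, the estimate for the step in this assay is a decrease of moderate size, beyond the scatter: a number 1.00 log units lower from compound 2 to compound 3 (beyond the scatter) is expected. Compound 3 is therefore estimated at 2 in this assay, within a range from 1.4 to 2.6.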

Compound 3, distribution coefficient: 3
Beside the measured number, compound 3's estimate is 1.00 log units below it; the whole stated range lies below it.
By their numbers in this assay, from the lowest: compound 1; then compounds 2 and 3 (each within the scatter of the next).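

In this assay, (hydroxycarbamoyl)methyl in place of 1-(hydroxycarbamoyl)-1-methylethyl on an amide-type nitrogen gives no change at the digits printed from compound 2 to compound 3 (within the scatter), so going from 7 heavy atoms to 5 in this chain leaves the read-out unmoved at the digits printed. Within the data shown here, the same compound 3 also gives the first measured step beyond the scatter: hydrogen in place of carbamoylmethyl on a saturated chain carbon bound to an amide-type nitrogen and a carbonyl carbon gives a number 2.00 log units higher from compound 1 to compound 3 (beyond the scatter), so within this short set the read-out answers to the carbamoylmethyl change and not to the change in the chain end. Nothing at hand bears on why these two changes differ so much in size.

The compounds shown leave open whether the large step belongs to carbamoylmethyl in particular or would also appear with a plain methyl, a carboxymethyl or an aminoethyl chain on that saturated carbon. They also leave open whether a longer chain such as 1-(hydroxycarbamoyl)propyl on the amide-type nitrogen would keep the read-out as flat as the step seen here.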